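This account rests on a few compounds, and the source may have more. Where it says the series, first, only, none or still open, it means among the compounds named here.

Measured compounds:
compound 1 `c1cc(N2CCCCC2)nc(Nc2ccc(Oc3ncnc4sccc34)cc2)n1` gives 4020 nM in a functional assay on A549 cells (Homo sapiens) for inhibition, read by MTT assay, with a stated time of 72 h; a lower number here means a stronger inhibitor, a higher number a weaker inhibitor
compound 2 `CN(c1ccc(Oc2ncnc3sccc23)cc1)c1nccc(N2CCCCC2)n1` gives 8790 nM in this assay
compound 3 `c1ccc2c(c1)CCN2c1ccnc(Nc2ccc(Oc3ncnc4sccc34)cc2)n1` gives "not active" (no number reported) in this assay; no number is reported for it

Compound 1 and compound 3 share the rest of the structure and differ in the core, (2,3-dihydro-1H-indol-1-yl in place of piperidin-1-yl on an aromatic carbon). From compound 1 to compound 2 the change is methyl in place of hydrogen on a nitrogen on an aromatic ring, and the step is a 2.2-fold higher number from compound 1 to compound 2 (0.34 log units; beyond the scatter). Compound 4 `CN(c1ccc(Oc2ncnc3sccc23)cc1)c1nccc(N2CCc3ccccc32)n1` carries the same change on the core of compound 3, (methyl in place of hydrogen on a nitrogen on an aromatic ring); the place is described in the same words in both pairs, so it is the same change. Compound 3 gave no number, and the earlier step raised the number, so compound 4 is expected to be weak as well, most probably reported without a number. Compound 4 is estimated at 40000 nM in this assay, with a range from 12000 nM to 150000 nM.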

Compound 4, half-maximal inhibitory concentration: 19600 nM
Compound 4: middle estimate off by 2.0-fold (0.31 log units), on the high side; low and high end bracket the measured number.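

In this assay, 2,3-dihydro-1H-indol-1-yl in place of piperidin-1-yl on an aromatic carbon gives a 2.2-fold higher number from compound 2 to compound 4 (0.35 log units; beyond the scatter), a modest step beyond the scatter, on the core carrying the methyl on the nitrogen. Going by these compounds, on the core of compound 1, which gives 4020 nM, the same change leads to compound 3, reported as not active without a number, so that step cannot be read and whether the size carries from one core to the other remains unknown. No measurement bears on the cause of the step.

Still open, on these data alone, is how this assay responds when a carboxylic acid or an open-chain amine stands in place of piperidin-1-yl on that aromatic carbon. Also open, as far as these compounds go, is whether a longer chain in place of the methyl on the nitrogen moves the number further.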